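This account rests on a few compounds, and the source may have more. Where it says the series, first, only, none or still open, it means among the compounds named here.

Of the compounds shown here, two have so far been tested in a functional assay on CEM-DNR-bulk cells (Homo sapiens), read by MTT assay, with a stated time of 72 h; on this read-out higher numbers stand for weaker inhibition and lower numbers for stronger inhibition. Compound 1 `CNc1ncnc2c1c(-c1ccoc1)cn2[C@@H]1O[C@H](CO)[C@@H](O)[C@H]1O` gives > 20000 nM, which is a limit of the assay and not a number. Compound 2 `Cc1ncnc2c1c(-c1ccoc1)cn2[C@@H]1O[C@H](CO)[C@@H](O)[C@H]1O` gives > 20000 nM, which is also a limit. Among the measured compounds shown here, the one measured step is therefore a step that the two limits leave unreadable from compound 1 to compound 2, with methyl in place of methylamino on an aromatic carbon. For the measured compounds named here, all the evidence comes down to the limit of > 20000 nM in this assay, at which 2 of the 2 values shown sit, so compound 2 has no exact value and no measured compound ranks above it.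

Compound 3 `Cc1ncnc2c1c(I)cn2[C@@H]1O[C@H](CO)[C@@H](O)[C@H]1O` keeps the rest of compound 2 but carries iodo in place of furan-3-yl on an aromatic carbon of a five-membered aromatic ring with 1 nitrogen: iodo in place of furan-3-yl on an aromatic carbon. Going by the values given here, no measured step touches this place, and the only step available has no readable size. The data therefore fix neither the size nor the direction of the change. The cautious expectation is that compound 3 stays close to the limit in this assay, with only a modest gain possible, and the assay may again report only a limit. The expected move is an at least 1.6-fold lower number from compound 2 to compound 3 (0.22 log units; that floor lies within the scatter). For compound 3 the estimated value is 12000 nM, with an expected range of 2500 nM to 20000 nM.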

Compound 3, half-maximal inhibitory concentration: 12600 nM
The estimate for compound 3 lay 1.1-fold (0.02 log units) below the measured number; the range from low to high includes it.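

Compound 3 is the first compound shown with an exact value in this assay, so a change on this aromatic carbon, two ring bonds from the ring nitrogen, can now be tied to a number. Compound 2 gives > 20000 nM, which is a limit of the assay and not a number. As far as these compounds go, replacing the five-heavy-atom furan-3-yl ring with a single iodine atom gives an at least 1.5-fold lower number from compound 2 to compound 3 (0.20 log units; that floor lies within the scatter), so only a floor for the step can be read, and its true size stays unknown.

From the compounds shown here alone, whether iodo would have the same effect with the methylamino group of compound 1 in place of the methyl group remains open, as does the outcome with other groups at this carbon, such as chloro, bromo, an amine or a longer alkyl chain. The step between the two compounds that sit at the limit cannot be read, and the series still offers only one exact value, with most of the picture resting on a single limit: the limit of > 20000 nM in this assay, at which 2 of the 3 values shown sit.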